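The compounds below may be only part of what the source reports. "The series", "measured", "known", "first", "only" and "open" are said of these compounds alone.

For the measured compounds named here, in a functional assay on HeLa cells (Homo sapiens) for inhibition, with a stated time of 72 h (a higher number here means a weaker inhibitor, a lower number a stronger inhibitor), compound 1 (`NC1CCC(Nc2nc(NCc3ccc(-c4ccco4)cc3)c3ncn(C4CCCC4)c3n2)CC1`) gives 71 nM, the lowest of the three numbers measured so far. Compound 3 (`OC1CCC(Nc2nc(NCc3ccc(-c4ccco4)nc3)c3ncn(C4CCCC4)c3n2)CC1`) gives 247 nM, and compound 2 (`CC(C)(O)CNc1nc(NCc2ccc(-c3ccco3)cc2)c2ncn(C3CCCC3)c2n1`) gives 14800 nM. Compound 4 (`Nc1ccccc1CNc1nc(NC2CCC(N)CC2)nc2c1ncn2C1CCCC1`) has not yet been measured. It keeps the 4-aminocyclohexyl group of compound 1 and differs from it as follows: 2-aminophenyl in place of 4-(furan-2-yl)phenyl on a saturated chain carbon bound to a nitrogen on an aromatic ring. In short, 2-aminophenyl stands in place of 4-(furan-2-yl)phenyl on a saturated chain carbon bound to a nitrogen on an aromatic ring.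

Going by the values given here, no measured step changes that place, and all three measured compounds carry a furan-2-yl group, so the data offer no direct precedent. Among the compounds with values here, the only step available, a 210-fold higher number from compound 1 to compound 2 (2.32 log units; beyond the scatter), replaces the 4-aminocyclohexyl group instead. Within the data shown here, it shows only that one change can move the number a long way. A higher number is therefore expected, though a smaller move than that one, with the estimated step being an 11-fold higher number from compound 1 to compound 4 (1.05 log units; beyond the scatter). Compound 4 is expected at 800 nM, with an estimated range from 150 nM to 5000 nM.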

Compound 4, half-maximal inhibitory concentration: 1030 nM
The estimate for compound 4 lay 1.3-fold (0.11 log units) below the measured number; low and high end bracket the measured number.
By their numbers in this assay, from the lowest: compound 1; then compound 3; then compound 4; then compound 2.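

In this assay, the group on a saturated chain carbon bound to a nitrogen on an aromatic ring proves to matter: 2-aminophenyl in place of 4-(furan-2-yl)phenyl gives a 15-fold higher number from compound 1 to compound 4 (1.16 log units; beyond the scatter) and shows that keeping the 4-aminocyclohexyl group does not by itself preserve the low number of compound 1. The change removes the furan-2-yl group and brings in an amine at once, so the step cannot separate the two. Nothing at hand explains the rise.

The compounds shown leave open how a plain phenyl group or a 4-methoxyphenyl group would read at this place, either of which would help to separate those two parts of the change. Also open, as far as these compounds go, is whether 2-aminophenyl would give a similar step alongside an aminoethyl chain in place of the 4-aminocyclohexyl group.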